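A Side-Chain Swap Tested in the Tail Flick Assay

A few compounds are considered here, and "the series" means these few. Any claim that something is new, unique, unknown or untested is made for them only; others in the source may bear on it.

compound 1 `O=C(CN(c1ncnc2c1ncn2C1CCCCO1)C1CC1)N[C@@H](CCC(=O)OCc1ccccc1)C(=O)OCc1ccccc1`: 14.1%
compound 2 `NC(=O)C[C@H](NC(=O)CN(c1nc(Cl)nc2[nH]cnc12)C1CC1)C(=O)O`: 7.51%

In a functional assay on the whole organism (Tail, strain ICR) with Mus musculus as the target, in the tail flick test, with a stated time of 150 min, at a dose of 25 umol/kg by the oral route (a lower number here means a weaker effect, a higher number a stronger effect of the compound at the dose given), compound 1 gives 14.1%, while compound 2 gives 7.51%. Compound 1 holds the larger of the two readings, but the gap to compound 2 lies within the usual scatter, so the two cannot be told apart. Compound 3 `CC(C)(C)OC(=O)NCCCC[C@H](NC(=O)CN(c1ncnc2c1ncn2C1CCCCO1)C1CC1)C(=O)OCc1ccccc1` differs from compound 1 by 2-((tert-butoxycarbonyl)amino)ethyl in place of benzyloxycarbonyl on a saturated chain carbon, three bonds along the chain from an amide-type nitrogen and a carbonyl carbon. For the measured compounds named here, no measured pair shows this change, so nothing tells how large its effect should be. The step of a number 1.1 percentage points lower from compound 1 to compound 3 (within the scatter) is expected to stay within the scatter. Compound 3 is therefore estimated at 13%, with a range from 3% to 28%.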

Compound 3, a percentage reported as activity, at one dose (the size of the read-out at that dose, not a potency): 17.2%
Compound 3: middle estimate off by 4.2 percentage points, on the low side; low and high end bracket the measured number.
By their numbers in this assay, from the lowest: compounds 2, 1 and 3 (each within the scatter of the next).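

In this assay, putting 2-((tert-butoxycarbonyl)amino)ethyl in place of benzyloxycarbonyl on this saturated chain carbon gives a number 3.1 percentage points higher from compound 1 to compound 3 (within the scatter). At this position, then, a group with no ring and a hydrogen-bond donor cannot be told apart from one carrying a six-membered aromatic ring and no donor. No measurement here explains this result. The compounds shown leave open whether a free amine or a carboxylic acid at the end of this chain would give a different reading, and whether a longer chain would.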